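Dimethylamino in Place of the Piperidine Amide: Expected Cytotoxicity

The source may report more compounds than this note shows. Statements on the series, on what has been measured and on what is new or still open speak of the compounds shown alone.

Compound 1 `CCCCn1cc(C(=O)O)c(=O)c2cc(F)c(N3CCC(C(N)=O)CC3)cc21` carries a free carboxylic acid on its core and a 4-carbamoylpiperidin-1-yl group on the aromatic ring. In an ADME assay on J774.1 cells (Mus musculus) for cytotoxicity, read by resazurin assay, with a stated time of 48 h (on this read-out lower numbers stand for stronger inhibition and higher numbers for weaker inhibition), compound 1 gives > 100000 nM, which is a limit of the assay and not a number. Compound 1 thus stands at the limit of > 100000 nM in this assay, at which 1 of the 3 values shown sits, the weakest end of what has been measured. Two amides of the same core were also measured: compound 2 `CCCCn1cc(C(=O)NCc2ccc(OC)cc2)c(=O)c2cc(F)c(N3CCC(C(N)=O)CC3)cc21` gives 40800 nM in this assay, and compound 3 `CCCCn1cc(C(=O)NCc2ccccc2)c(=O)c2cc(F)c(N3CCC(C(N)=O)CC3)cc21` gives 47000 nM. Both of those steps leave the aromatic substituent untouched. The change in an at least 2.4-fold lower number from compound 1 to compound 2 (0.38 log units; beyond the scatter) and in an at least 2.1-fold lower number from compound 1 to compound 3 (0.32 log units; beyond the scatter) sits on the carbonyl carbon, and the change in a 1.2-fold higher number from compound 2 to compound 3 (0.06 log units; within the scatter) sits on the amide's own aromatic ring. For the measured compounds named here, none of the measured steps therefore bears on the change now considered, which keeps the acid and alters the aromatic substituent: dimethylamino in place of 4-carbamoylpiperidin-1-yl on an aromatic carbon. Going by the values given here, compound 4 `CCCCn1cc(C(=O)O)c(=O)c2cc(F)c(N(C)C)cc21` is the only compound in which that substituent is varied, so no measured step gives a direction. Since compound 1 already sits at the limit, the acid form appears weak in this read-out. Compound 4 is therefore expected to show no step beyond the scatter, with a step that the limit leaves unreadable from compound 1 to compound 4 as the expected change. Compound 4 is estimated to give 120000 nM, within a range from 40000 nM to 400000 nM, most likely again reported only as a limit.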

Compound 4, half-maximal inhibitory concentration: > 100000 nM
Compound 4: no number, only a limit (the forecaster's own chance of this, stated with the estimate: 65%); the middle value lies beyond the limit too.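

In this assay compound 1 and compound 4 are both reported only as limits and not as numbers, so no step between them can be read: the limit of > 100000 nM in this assay, at which 2 of the 4 values shown sit.

The compounds shown leave open whether dimethylamino in place of 4-carbamoylpiperidin-1-yl changes the read-out at all, in the acids or in amides such as compound 2 and compound 3.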